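The compounds below may be only part of what the source reports. "The series", "measured", "known", "first", "only" and "open" are said of these compounds alone.

Compound 1 `N=c1oc2ccccc2cc1C(=O)N/N=C1\C(=O)Nc2ccc(S(=O)(=O)N3CCOCC3)cc21`: 132000 nM
Compound 2 `N/N=C1\C(=O)Nc2ccc(S(=O)(=O)N3CCOCC3)cc21`: 391000 nM
Compound 3 `O=C1Nc2ccc(S(=O)(=O)N3CCOCC3)cc2/C1=N/NC(=O)c1ccccc1`: 295000 nM

All three values come from an ADME assay on WI-38 cells (Homo sapiens) for cytotoxicity, read by sulforhodamine B assay, with a stated time of 24 h; on this read-out lower numbers stand for stronger inhibition and higher numbers for weaker inhibition. Compound 3, at 295000 nM, holds the second highest of the three numbers, but it cannot be separated from compound 2 and stands clear only of compound 1. The next compound, compound 4 `O=C1Nc2ccc(S(=O)(=O)N3CCOCC3)cc2/C1=N/c1ccc(Cl)cc1`, carries 4-chlorophenyl in place of benzamido on a double-bonded nitrogen. Among the compounds with values here, no measured step makes this exact change, and no measured compound carries 4-chlorophenyl, so the evidence is indirect. Within the data shown here, two steps bear on it. Adding benzoyl in place of hydrogen on an amine nitrogen gave a 1.3-fold lower number from compound 2 to compound 3 (0.12 log units; within the scatter). Exchanging the group on the carbonyl carbon gave a 2.2-fold higher number from compound 1 to compound 3 (0.35 log units; beyond the scatter), which is modest. Since these changes moved the number so little, only a small shift is expected in this assay, and none clearly beyond the scatter. The estimated step is a 1.4-fold lower number from compound 3 to compound 4 (0.15 log units; within the scatter). The estimate for compound 4 is 210000 nM, with an expected range from 90000 nM to 420000 nM.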

Compound 4, half-maximal inhibitory concentration: 468000 nM
Beside the measured number, compound 4's estimate is 2.2-fold (0.35 log units) below it; the whole stated range lies below it.
By their numbers in this assay, from the lowest: compound 1; then compounds 3, 2 and 4 (each within the scatter of the next).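

On the double-bonded nitrogen, the two new changes stay small in this assay with a 1.6-fold higher number from compound 3 to compound 4 (0.20 log units; within the scatter) for 4-chlorophenyl in place of benzamido and a 1.2-fold higher number from compound 2 to compound 4 (0.08 log units; within the scatter) for 4-chlorophenyl in place of amino as the steps read. The earlier compounds shown here had compared only amino and benzamido here, whereas 4-chlorophenyl carries none of the hydrogen-bond donors or acceptors counted for benzamido, and it still cannot be told apart from either group in this read-out. Nothing given here accounts for this result.

The compounds shown leave open whether any group on this nitrogen can move the number beyond the scatter, for instance a carboxylic acid or a longer chain in place of 4-chlorophenyl. They also leave open whether an amine on the phenyl ring in place of the chlorine would change the picture.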